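Methoxy walk on the aryl ring of two chalcone cores

The compounds below may be only part of what the source reports. "The series", "measured", "known", "first", "only" and "open" are said of these compounds alone.

Compound 1 `COc1ccc(/C=C/C(=O)c2ccccc2-c2cccc(F)c2)cc1` gives 640 nM in a functional assay on MCF7 cells (Homo sapiens) for antiproliferative activity, read by sulforhodamine B assay, with a stated time of 48 h; a higher number here means a weaker inhibitor, a lower number a stronger inhibitor. Compound 2 `COc1ccc(/C=C/C(=O)c2ccccc2-c2cccc(F)c2)cc1OC` differs from it by methoxy in place of hydrogen on an aromatic carbon, and in this assay compound 2 gives 1200 nM; the step of a 1.9-fold higher number from compound 1 to compound 2 (0.27 log units; within the scatter) lies within the scatter. Compound 3 `COc1ccc(C(=O)/C=C/c2ccccc2-c2ccc(F)cc2)cc1OC` carries a different core; how the two cores differ is not broken down here. In this assay compound 3 gives 7100 nM, the highest number of the three measured, with compound 2 nearest and compound 1 furthest, both gaps beyond the scatter.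

Compound 4 `COc1cc(C(=O)/C=C/c2ccccc2-c2ccc(F)cc2)cc(OC)c1OC` is not yet measured. It differs from compound 3 by methoxy in place of hydrogen on an aromatic carbon. Among the compounds with values here, this is the same kind of change as the one from compound 1 to compound 2, though the surroundings are not identical: in compound 4 the entering methoxy is also meta to a methoxy group, whereas in compound 2 it is ortho to a methoxy group and meta to a large group only. Within the data shown here, only one measured instance of the change exists, so the expectation rests on that single step, a 1.9-fold higher number from compound 1 to compound 2 (0.27 log units; within the scatter), and on the value of compound 3, 7100 nM.

For compound 4 the expected step is a 1.4-fold higher number from compound 3 to compound 4 (0.15 log units; within the scatter), a small shift in the same direction as the earlier one. The estimate for compound 4 in this assay is 10000 nM, expected to fall between 4000 nM and 25000 nM.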

Compound 4, half-maximal inhibitory concentration: 9100 nM
Compound 4: the middle estimate sits 1.1-fold (0.04 log units) above what was measured; the measured number falls inside the stated range.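

Methoxy in place of hydrogen on an aromatic carbon now has two readings in this assay, and the new one is a 1.3-fold higher number from compound 3 to compound 4 (0.11 log units; within the scatter). The two readings agree: the same change on two cores in this assay, a 1.9-fold higher number (0.27 log units; within the scatter) from compound 1 to compound 2 and a 1.3-fold higher number (0.11 log units; within the scatter) from compound 3 to compound 4, 1.5-fold (0.17 log units) apart, within the scatter of two such steps. On these two cores, then, neither step can be told from the scatter, so the change can be carried from the core of compound 1 to the core of compound 3 with a small step as the working expectation, but the two steps do not show that methoxy has any real effect here, and they say nothing about a third core or about other places on these rings.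

Left open is whether a group other than methoxy, such as an amine, a carboxylic acid or a longer chain like butoxy, would give a step beyond the scatter if it entered at the same place on either core. Also open is which of the differences between the two cores matters in this assay, since no pair of compounds shown separates any one of those differences from the others.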